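From methoxy to fluoro on compound 1

The source may report more compounds than this note shows. Statements on the series, on what has been measured and on what is new or still open speak of the compounds shown alone.

Of the compounds shown here, three sharing one core have been measured in a functional assay on MCF7 cells (Homo sapiens) for antiproliferative activity, read by MTT assay; on this read-out higher numbers stand for weaker inhibition and lower numbers for stronger inhibition. Within the data shown here, compound 1 (`COc1ccc(-c2ccnc(Nc3ccc([N+](=O)[O-])cc3)n2)cc1`) gives 770 nM and holds the lowest number so far. Compound 2 (`COc1cccc(Nc2nccc(-c3ccc(F)cc3)n2)c1`) gives 412000 nM on the same read-out, a number far higher and well beyond the scatter. Compound 3 (`Cc1ccc(-c2ccnc(Nc3ccc(Cl)cc3Cl)n2)cc1`) gives > 1000000 nM here, and this is a limit of the assay, not a number.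

Compound 4 (`O=[N+]([O-])c1ccc(Nc2nccc(-c3ccc(F)cc3)n2)cc1`) has not yet been measured. It carries fluoro in place of methoxy on an aromatic carbon, para to a large group (fluoro in place of methoxy on an aromatic carbon), so that 4-methoxyphenyl becomes 4-fluorophenyl.

Among the measured compounds shown here, no measured pair shows this change alone, so the expectation rests on thin ground. Compound 2 already carries the 4-fluorophenyl group and gives 412000 nM in this assay, although the rest of its structure differs from that of compound 4. That value points towards some weakening, so a higher number is expected, beyond the scatter but well short of the whole gap between compound 1 and compound 2. The expected step is a 5.2-fold higher number from compound 1 to compound 4 (0.72 log units; beyond the scatter) on this estimate. For compound 4 the estimated value is 4000 nM in this assay, with an expected range from 500 nM to 40000 nM at its two ends.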

Compound 4, half-maximal inhibitory concentration: 400 nM
Compound 4: the middle estimate sits 10-fold (1.00 log units) above what was measured; measured number outside the range, below it.
By their numbers in this assay, from the lowest: compounds 4 and 1 (each within the scatter of the next); then compound 2. At a limit, above all of these: compound 3.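

At this place, on an aromatic carbon para to a large group, replacing methoxy with fluoro gives a 1.9-fold lower number from compound 1 to compound 4 (0.28 log units; within the scatter) in this assay, so compound 1 and compound 4 cannot be told apart on this read-out. Among these compounds, the earlier compounds could not show this, as none of them formed a pair differing in this one place, and the only hint came from compound 2, which carries the same 4-fluorophenyl group and gives 412000 nM, whereas compound 4 gives 400 nM. The 4-fluorophenyl group alone therefore does not bring a number as high as that of compound 2, and compound 4 keeps the nitro group of compound 1, but nothing measured here explains why the two groups read so alike.

On these data alone, it remains open whether another group at this place, such as an amine, a carboxylic acid or a longer chain, would also stay within the scatter of compound 1 or move the number beyond it. As far as these compounds go, it also remains open whether methoxy and fluoro would stay this close in a compound without the nitro group.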